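Bromine added to compound 1: expected effective dose

The compounds below may be only part of what the source reports. "The series", "measured", "known", "first", "only" and "open" are said of these compounds alone.

Three compounds of this series have been run in a functional assay on the whole organism with Mus musculus as the target, with a stated time of 15 min; on this read-out higher numbers stand for an effect only at larger amounts of compound and lower numbers for an effect already at smaller amounts. Compound 1 `CCc1ccc(C2C=CN=CN2)s1` gives 10 mg/kg in this assay. Compound 3 `Cc1sc2c(c1C1C=CN=CN1)CCCC2` gives 10 mg/kg in this assay, level with compound 1 at the digits shown, and together these two hold the lowest numbers of the three. Compound 2 `Cc1sc2ccccc2c1C1NC(N)=NC=C1Cl` gives 30 mg/kg in this assay, a higher number than compound 1 and beyond the usual scatter. No pair among these three differs in only one place, so no single-change step can be read from the measured set.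

Compound 4 `CCc1cc(Br)c(C2C=CN=CN2)s1` has not been measured. It differs from compound 1 as follows: bromo in place of hydrogen on an aromatic carbon. Bromo in place of hydrogen on an aromatic carbon of a five-membered aromatic ring with 1 sulfur is the whole change; the remainder of compound 1 is kept.

With no measured step of this kind in the series, the expected step is none beyond the scatter, estimated as no change at the digits printed from compound 1 to compound 4 (within the scatter). Compound 4 is expected to give 10 mg/kg in this assay, with a range from 5 mg/kg to 30 mg/kg. The chance that only a limit is reported is taken as small.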

Compound 4, minimum effective dose: 30 mg/kg
Beside the measured number, compound 4's estimate is 3.0-fold (0.48 log units) below it; low and high end bracket the measured number.
By their numbers in this assay, from the lowest: compounds 1 and 3 (each within the scatter of the next); then compounds 2 and 4 (each within the scatter of the next).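

In this assay, going by these compounds alone, this position is not silent: bromo in place of hydrogen on an aromatic carbon of the five-membered aromatic ring with 1 sulfur, next to the ring atom that bears a group of 6 heavy atoms, gives a 3.0-fold higher number from compound 1 to compound 4 (0.48 log units; beyond the scatter) and this is the only single-change step available. The step is modest in size, but it shows that this ring carbon of the core of compound 1 does not take bromo without a shift toward larger amounts of compound. No measurement on the compounds shown speaks to the origin of this shift, so the step stands as an observation without an explanation.

As far as these compounds go, with a single group at this carbon, it remains open whether the shift belongs to bromine itself or to any group placed there, a question that fluoro, chloro, methyl or methoxy at the same carbon would help to settle. From the compounds shown here alone, it is equally open whether bromo would have a similar effect alongside a longer chain in place of the ethyl group, or whether an amine or a carboxylic acid at this carbon would move the number in the same direction.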